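This account rests on a few compounds, and the source may have more. Where it says the series, first, only, none or still open, it means among the compounds named here.

Working notes, spiroimidazolidinone series. Compound 1 `CC1CCCN(C(=O)CN2CN(c3ccccc3)C3(CCN(C(=O)c4ccc(C(C)(C)C)cc4)CC3)C2=O)C1` gives 12000 nM in an assay on HEK293 cells for displacement of a labelled ligand from NPC1-like intracellular cholesterol transporter 1 (Homo sapiens); a lower number here means a stronger inhibitor, a higher number a weaker inhibitor. Compound 2 `CC(C)(C)c1ccc(C(=O)N2CCC3(CC2)C(=O)N(CC(=O)NCCCCO)CN3c2ccccc2)cc1` gives 19200 nM in this assay; of the two numbers shown it sits next to compound 1, since a 1.6-fold higher number from compound 1 to compound 2 (0.20 log units; within the scatter). Compound 3 `CC(C)(C)c1ccc(C(=O)N2CCC3(CC2)C(=O)N(CC(=O)N2CCCC(C(N)=O)C2)CN3c2ccccc2)cc1` carries 3-carbamoylpiperidin-1-yl in place of (4-hydroxybutyl)amino on a carbonyl carbon. Within the data shown here, the only measured step that bears on it is the exchange of the amide substituent on that carbonyl carbon, a 1.6-fold higher number from compound 1 to compound 2 (0.20 log units; within the scatter), which stayed within the scatter although a ring left for an open chain. Returning to a piperidinyl amide is therefore expected to bring no step beyond the scatter, a 1.4-fold lower number from compound 2 to compound 3 (0.14 log units; within the scatter). Compound 3 is estimated at 14000 nM, range 5000 nM to 40000 nM.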

Compound 3, half-maximal inhibitory concentration: 16900 nM
Compound 3: the middle estimate sits 1.2-fold (0.08 log units) below what was measured; the range from low to high includes it.
By their numbers in this assay, from the lowest: compounds 1, 3 and 2 (each within the scatter of the next).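

On the carbonyl carbon, 3-carbamoylpiperidin-1-yl in place of (4-hydroxybutyl)amino gives a 1.1-fold lower number from compound 2 to compound 3 (0.06 log units; within the scatter) in this assay, so this ring-bearing amide and the open chain cannot be told apart. On the saturated ring carbon, carbamoyl in place of methyl gives a 1.4-fold higher number from compound 1 to compound 3 (0.15 log units; within the scatter), so neither substituent separates compound 1 from compound 3 in this series. No evidence bears on why these changes leave the values within the scatter.

On these data alone, whether any group on this carbonyl carbon can produce a step beyond the scatter remains open. A carboxylic acid or an amine on the piperidine ring would test this further.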